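Imidazole thioether linker series: from compound 2 to compound 3

The source may report more compounds than this note shows. Statements on the series, on what has been measured and on what is new or still open speak of the compounds shown alone.

Going by the values given here, compound 2 `Cn1ccnc1SCCCCSc1nc(-c2ccccc2)c(-c2ccccc2)[nH]1` holds the lowest number of the two measured so far: in an assay for inhibition of acyl-CoA:cholesterol acyltransferase (Oryctolagus cuniculus) (a lower number here means a stronger inhibitor, a higher number a weaker inhibitor), compound 2 gives 180 nM. Among the compounds with values here, the only other measured member, compound 1 `Cn1ccnc1S(=O)(=O)CCCSc1nc(-c2ccccc2)c(-c2ccccc2)[nH]1`, differs at the sulfur bridge; in this assay compound 1 gives 8000 nM. Within the data shown here, the single measured step, a 44-fold lower number from compound 1 to compound 2 (1.65 log units; beyond the scatter), concerns that sulfonyl versus sulfanyl bridge alone.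

Compound 3 `c1ccc(-c2nc(SCCCCCSc3ncc[nH]3)[nH]c2-c2ccccc2)cc1` is not yet measured. Its change from compound 2 is ((1H-imidazol-2-yl)sulfanyl)methyl in place of (1-methyl-1H-imidazol-2-yl)sulfanyl on a saturated chain carbon, four bonds along the chain from a sulfur. Among the measured compounds shown here, no measured step bears on this change: the step of a 44-fold lower number from compound 1 to compound 2 (1.65 log units; beyond the scatter) swapped sulfonyl for sulfanyl, whereas here the methyl on the imidazole leaves and the linking chain lengthens, with the same atoms joined differently. For the measured compounds named here, with no precedent, the expectation for compound 3 is a step of a 1.1-fold higher number from compound 2 to compound 3 (0.05 log units; within the scatter) in this assay, that is none beyond the scatter, with a wide range to reflect the absence of guidance. The estimated value for compound 3 is 200 nM with a range from 50 nM to 800 nM.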

Compound 3, half-maximal inhibitory concentration: 880 nM
Beside the measured number, compound 3's estimate is 4.4-fold (0.64 log units) below it; measured number above the stated range.
By their numbers in this assay, from the lowest: compound 2; then compound 3; then compound 1.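

In this assay, the position on a saturated chain carbon, four bonds along the chain from a sulfur, proves sensitive even to a change that keeps the same atoms, joined differently: ((1H-imidazol-2-yl)sulfanyl)methyl in place of (1-methyl-1H-imidazol-2-yl)sulfanyl gives a 4.9-fold higher number from compound 2 to compound 3 (0.69 log units; beyond the scatter), whereas the earlier step spoke only to the sulfonyl versus sulfanyl bridge. Measured against the sulfonyl member, the change to 2-((1H-imidazol-2-yl)sulfanyl)ethyl gives a 9.1-fold lower number from compound 1 to compound 3 (0.96 log units; beyond the scatter), which places compound 3 in the middle of the three, although this step also folds the loss of the methyl and the longer chain into the bridge change. Nothing available accounts for the rise from compound 2 to compound 3.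

The loss of the methyl and the lengthening of the chain arrive together in compound 3, so the compounds shown do not separate their contributions; that would take the 1-methyl-1H-imidazol-2-yl group on the longer chain, or the 1H-imidazol-2-yl group on the shorter one. Also open, as far as these compounds go, is how the series reads with a still longer chain, or with an amine or a carboxylic acid in place of the imidazole.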